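Shortening the Piperidine Side Chain in a Melanocortin Series

The compounds below may be only part of what the source reports. "The series", "measured", "known", "first", "only" and "open" are said of these compounds alone.

Two measured compounds share one core and differ only in the chain that carries a piperidine ring. In an assay for binding affinity to Melanocortin receptor 4 (Homo sapiens) (on this read-out lower numbers stand for stronger inhibition and higher numbers for weaker inhibition), compound 1 `COc1ccc(Br)cc1CCc1c(F)cccc1C(=O)/N=C(\N)NCCCN1CCCCC1` gives 3.2 nM. In this assay compound 2 `COc1ccc(Br)cc1CCc1c(F)cccc1C(=O)/N=C(\N)NCCCCN1CCCCC1` gives 0.58 nM. Among the compounds with values here, the single measured step is a 5.5-fold lower number from compound 1 to compound 2 (0.74 log units; beyond the scatter). Within the data shown here, compound 2 therefore stands with the lowest of the two numbers, and its only neighbour, compound 1, sits beyond the scatter above it.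

Compound 3 `COc1ccc(Br)cc1CCc1c(F)cccc1C(=O)/N=C(\N)NCC1CCNCC1` has not yet been measured. Set against compound 2 it carries piperidin-4-yl in place of 3-(piperidin-1-yl)propyl on a saturated chain carbon bound to an amine nitrogen. Among the measured compounds shown here, only one measured step bears on this change, a 5.5-fold lower number from compound 1 to compound 2 (0.74 log units; beyond the scatter), in which a longer chain between the amine nitrogen and the piperidine ring went with a lower number. For the measured compounds named here, compound 3 goes the other way, leaving no chain at all between that nitrogen and the ring, so a step toward higher numbers is expected, beyond the scatter yet uncertain, since no measured compound shows this arrangement. Compound 3 is expected to give about 5 nM in this assay. The estimated range for compound 3 runs from 1.2 nM to 25 nM. This estimate amounts to an 8.6-fold higher number from compound 2 to compound 3 (0.94 log units; beyond the scatter).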

Compound 3, inhibition constant: 13 nM
The estimate for compound 3 lay 2.6-fold (0.41 log units) below the measured number; the range from low to high includes it.
By their numbers in this assay, from the lowest: compound 2; then compound 1; then compound 3.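

In this assay, within the data shown here, piperidin-4-yl in place of 3-(piperidin-1-yl)propyl gives a 22-fold higher number from compound 2 to compound 3 (1.35 log units; beyond the scatter), a large step that shows this position responds more strongly than the single earlier step could reveal. Set against the 2-(piperidin-1-yl)ethyl group, the same piperidin-4-yl gives a 4.1-fold higher number from compound 1 to compound 3 (0.61 log units; beyond the scatter), so the group with the shortest reach from the amine nitrogen also carries the highest number of the three, and no compound shown goes against that order. Nothing measured here explains why the number rises.

The change to compound 3 alters more than reach, since the ring is attached through a carbon rather than through its nitrogen and the entering group has 1 hydrogen-bond donor where the leaving group has 0, and the compounds shown cannot separate these differences. As far as these compounds go, a 3-(piperidin-4-yl)propyl chain, or a piperidin-4-yl ring with a methyl group on its nitrogen, would each change one of these features alone, and how either behaves at this position remains open.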